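Phenyl in Place of 3,4-Dichlorophenyl: Clearance Outlook

This account rests on a few compounds, and the source may have more. Where it says the series, first, only, none or still open, it means among the compounds named here.

Two compounds sharing one core have so far been run in an ADME assay on cells (Hepatocyte, Homo sapiens) for metabolic stability, read by LC-MS, with a stated time of 60 min, tested at 1 uM; on this read-out higher numbers stand for fast clearance and lower numbers for slow clearance. Compound 1 `COc1cc(N(CC2CC2)c2ccc(Cl)c3ccccc23)cnc1C(=O)[C@H]1C[C@@H]1C(=O)O` gives 5 uL/min in this assay. Compound 2 `COc1cc(N(CC2CC2)c2ccc(Cl)c(Cl)c2)cnc1C(=O)[C@H]1C[C@@H]1C(=O)O` gives 4.3 uL/min in this assay. On the numbers as written, compound 2 holds the smaller of the two values, and its nearest neighbour is compound 1; that gap lies within the usual scatter of repeated runs, so the two compounds read alike and neither can be called the slower or the faster one.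

Compound 3 `COc1cc(N(CC2CC2)c2ccccc2)cnc1C(=O)[C@H]1C[C@@H]1C(=O)O` has not been measured. It differs from compound 2 in a single place: phenyl in place of 3,4-dichlorophenyl on a nitrogen on an aromatic ring. For the measured compounds named here, no pair among the measured compounds differs in only one place, so there is no measured step to lean on for this change. The change from compound 2 to compound 3 is expected to be a 1.4-fold higher number from compound 2 to compound 3 (0.14 log units; within the scatter), a step close to the scatter and of uncertain direction. Compound 3 is therefore expected to give about 6 uL/min in this assay, with a likely range from 2.5 uL/min to 14 uL/min.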

Compound 3, intrinsic clearance in a liver preparation (reported as CLH), per the amount of preparation that the assay uses: 3 uL/min
The estimate for compound 3 lay 2.0-fold (0.30 log units) above the measured number; measured number inside the range.
By their numbers in this assay, from the lowest: compounds 3, 2 and 1 (each within the scatter of the next).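

In this assay, phenyl in place of 3,4-dichlorophenyl on a nitrogen on an aromatic ring gives a 1.4-fold lower number from compound 2 to compound 3 (0.16 log units; within the scatter), so compounds 2 and 3 read alike. For the compounds shown here, this is the first single-place step measured, and it shows that, on this core, both chlorine atoms can be absent without the clearance number moving beyond the usual scatter of repeated measurements. No measurement shown here explains why the two compounds read alike.

Still open, as far as these compounds go, is whether a group of a different kind on this phenyl, such as a nitrile or an amine, would also leave the number within the scatter of compound 3. From the compounds shown here alone, it is also open whether a single chlorine, or a pyridyl ring in place of the phenyl, would read like compounds 2 and 3, since one step at one position cannot show how far this result extends.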